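Working notes: swapping the outer aromatic ring of the series

The source may hold more compounds than are shown below. What is called first, only, known or untested is meant among the compounds shown, and "the series" means these compounds.

Measured in an assay on isolated protein for inhibition of Dihydrofolate reductase (Homo sapiens), using NADPH, with a stated time of 5 min; a higher number here means a weaker inhibitor, a lower number a stronger inhibitor:
compound 1 `CCc1nc(N)nc(N)c1C#CC(C)c1ccc(-c2ccccc2)cc1OC` — 172 nM
compound 2 `CCc1nc(N)nc(N)c1C#CC(C)c1ccc(-c2ccncc2)cc1OC` — 127 nM

For the measured compounds named here, compound 2 has the smaller of the two numbers, but the only step bearing on it, a 1.4-fold lower number from compound 1 to compound 2 (0.13 log units; within the scatter), lies within the scatter, so compound 1 and compound 2 are not separated by these data.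

The next compound, compound 3 `CCc1nc(N)nc(N)c1C#CC(C)c1ccc(-c2ccc(C)cc2)cc1OC`, carries 4-methylphenyl in place of pyridin-4-yl on an aromatic carbon. Going by the values given here, the one measured step that bears on this change is the reverse of the one just described: phenyl for pyridin-4-yl gave a 1.4-fold lower number from compound 1 to compound 2 (0.13 log units; within the scatter), within the scatter. Among the compounds with values here, compound 3 differs from compound 1 only by the methyl on the outer ring, for which no step is available here. The expectation for compound 3 is therefore a number close to that of compound 1, i.e. a step of a 1.3-fold higher number from compound 2 to compound 3 (0.13 log units; within the scatter) from compound 2, not resolved from the scatter. Compound 3 is estimated at 170 nM in this assay, with a range from 80 nM to 360 nM.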

Compound 3, half-maximal inhibitory concentration: 208 nM
The estimate for compound 3 lay 1.2-fold (0.09 log units) below the measured number; the measured number falls inside the stated range.
By their numbers in this assay, from the lowest: compounds 2, 1 and 3 (each within the scatter of the next).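

Both new steps bear on the outer ring on the aromatic carbon para to a large group: in this assay the exchange of pyridin-4-yl for 4-methylphenyl gives a 1.6-fold higher number from compound 2 to compound 3 (0.21 log units; within the scatter), and methyl in place of hydrogen on the outer ring gives a 1.2-fold higher number from compound 1 to compound 3 (0.08 log units; within the scatter). Neither change resolves from the scatter, so phenyl, pyridin-4-yl and 4-methylphenyl, the three outer rings shown, are not separated at this place, and the methyl, which had no step of its own until now, adds no measurable difference in this assay. No independent measurement is available that could account for these three numbers lying so close together.

All three groups are six-membered aromatic rings, so the compounds shown leave open whether any change at this place gives a step beyond the scatter, for instance a saturated amine such as piperidine in place of the outer ring. As far as these compounds go, it also remains open whether a carboxylic acid or a longer alkyl chain in place of the methyl of 4-methylphenyl would separate from compound 3.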